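Dropping the aryl group from a sulfonylamidine naphthoquinone series

A few compounds are considered here, and "the series" means these few. Any claim that something is new, unique, unknown or untested is made for them only; others in the source may bear on it.

Measured compounds:
compound 1 `Cc1ccc(S(=O)(=O)/N=C(/CCNC2=CC(=O)c3ccccc3C2=O)Nc2cccc(C)c2)cc1`: 56200 nM
compound 2 `Cc1ccc(S(=O)(=O)/N=C(/CCNC2=CC(=O)c3ccccc3C2=O)Nc2ccc(F)c(F)c2)cc1`: 55200 nM
compound 3 `Cc1ccc(S(=O)(=O)/N=C(/CCNC2=CC(=O)c3ccccc3C2=O)Nc2ccc(Cl)cc2Cl)cc1`: 41900 nM

In an ADME assay on HEK293 cells (Homo sapiens) for cytotoxicity, read by MTT assay, with a stated time of 48 h (a higher number here means a weaker inhibitor, a lower number a stronger inhibitor), compound 1 gives 56200 nM, the top of the three numbers shown, yet its two neighbours sit within the scatter: a 1.0-fold lower number from compound 1 to compound 2 (0.01 log units; within the scatter) and a 1.3-fold lower number from compound 1 to compound 3 (0.13 log units; within the scatter). Compound 4 `Cc1ccc(S(=O)(=O)/N=C(\N)CCNC2=CC(=O)c3ccccc3C2=O)cc1` differs from compound 1 by hydrogen in place of 3-methylphenyl on an amine nitrogen. Within the data shown here, none of the measured steps removes the aryl group; each swaps one aryl for another, and a 1.3-fold lower number from compound 2 to compound 3 (0.12 log units; within the scatter) is, like the other two, within the scatter. So no step bears directly on this change, and no movement beyond the scatter is expected. Compound 4 is therefore estimated at 55000 nM, with a range from 22000 nM to 140000 nM. The expected step is a 1.0-fold lower number from compound 1 to compound 4 (0.01 log units; within the scatter), reflecting the wide uncertainty of an untested change.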

Compound 4, half-maximal inhibitory concentration: 63100 nM
Compound 4: the middle estimate sits 1.1-fold (0.06 log units) below what was measured, within the range that was stated.
By their numbers in this assay, from the lowest: compounds 3, 2, 1 and 4 (each within the scatter of the next).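

In this assay, replacing the aryl group with hydrogen on this amine nitrogen leaves every reading within the scatter (a 1.1-fold higher number from compound 1 to compound 4 (0.05 log units; within the scatter)) (a 1.1-fold higher number from compound 2 to compound 4 (0.06 log units; within the scatter)) (a 1.5-fold higher number from compound 3 to compound 4 (0.18 log units; within the scatter)). Among these compounds, the earlier compounds showed only that one aryl group could replace another, whereas these steps show that, in this small set, the value does not depend on an aryl group being present at this position. No available measurement explains this flat result. Still open, from the compounds shown here alone, is whether a methyl group, a longer alkyl chain or a carboxylic acid on this nitrogen would read the same.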